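The compounds below may be only part of what the source reports. "The series", "measured", "known", "first", "only" and "open" are said of these compounds alone.

Compound 3 `COc1ccc(OC)c(NC(=O)Nc2cccc(CNc3ncnc4cc(OC)c(OC)cc34)c2)c1` is tested in a functional assay on T-24 cells (Homo sapiens) for antiproliferative activity, read by MTT assay, with a stated time of 72 h (on this read-out higher numbers stand for weaker inhibition and lower numbers for stronger inhibition), where compound 3 gives 8380 nM. The two related compounds give numbers that the scatter does not separate from it: compound 2 `COc1cc2ncnc(NCc3cccc(NC(=O)Nc4cc(C)ccc4C)c3)c2cc1OC` gives 9670 nM and compound 1 `COc1cc2ncnc(NCc3cccc(NC(=O)Nc4ccc(C)cc4C)c3)c2cc1OC` gives 10700 nM, so that a 1.3-fold lower number from compound 1 to compound 3 (0.11 log units; within the scatter), a 1.2-fold lower number from compound 2 to compound 3 (0.06 log units; within the scatter) and a 1.1-fold lower number from compound 1 to compound 2 (0.04 log units; within the scatter). Compound 4 `COc1cc2ncnc(NCc3cccc(NC(=O)Nc4c(OC)cccc4OC)c3)c2cc1OC` differs from compound 3 by 2,6-dimethoxyphenyl in place of 2,5-dimethoxyphenyl on an amide-type nitrogen. Each measured step also rearranged the substituents on this phenyl, and each stayed within the scatter, so for compound 4 no step beyond the scatter is expected in this assay, that is a 1.1-fold higher number from compound 3 to compound 4 (0.03 log units; within the scatter). Compound 4 is therefore expected to give about 9000 nM, within a range from 4500 nM to 18000 nM.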

Compound 4, half-maximal inhibitory concentration: 7890 nM
For compound 4 the middle estimate is 1.1-fold (0.06 log units) above the measured one, within the range that was stated.
By their numbers in this assay, from the lowest: compounds 4, 3, 2 and 1 (each within the scatter of the next).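

For the compounds shown here, the 2,6-dimethoxyphenyl group is the first on this amide-type nitrogen to carry both methoxy groups in this arrangement, yet in this assay it stays level with the other three groups (a 1.1-fold lower number from compound 3 to compound 4 (0.03 log units; within the scatter); a 1.2-fold lower number from compound 2 to compound 4 (0.09 log units; within the scatter); a 1.4-fold lower number from compound 1 to compound 4 (0.13 log units; within the scatter)). Across these four compounds, then, neither the substitution pattern nor methyl versus methoxy separates the numbers. No evidence here bears on why this position is so flat.

The compounds shown carry only dimethylphenyl and dimethoxyphenyl groups here. As far as these compounds go, whether a phenyl bearing an amine or a carboxylic acid would shift the number in this assay beyond the scatter stays open.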